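A few compounds are considered here, and "the series" means these few. Any claim that something is new, unique, unknown or untested is made for them only; others in the source may bear on it.

Compound 1 `O=C1O/C(=C\Cn2cc(-c3cc(F)cc(F)c3)nn2)C(OCc2ccccc2)=C1OCc1ccccc1` is the starting point of this comparison. In a functional assay on CFPAC-1 cells (Homo sapiens) for antiproliferative activity, read by MTT assay, with a stated time of 72 h (a lower number here means a stronger inhibitor, a higher number a weaker inhibitor), compound 1 gives "not active" (no number reported), so no single number describes it. Two related compounds give limits of the assay rather than numbers. Compound 2 `O=C1O[C@H]([C@@H](O)Cn2cc(CCO)nn2)C(OCc2ccccc2)=C1OCc1ccccc1` gives > 100000 nM in this assay, which is a limit. Compound 3 `COc1ccccc1-c1cn(C[C@H](O)[C@H]2OC(=O)C(OCc3ccccc3)=C2OCc2ccccc2)nn1` gives > 100000 nM in this assay, again a limit. Among the compounds with values here, the only measured step, a step that the two limits leave unreadable from compound 2 to compound 3, therefore cannot be read, even though it brings in the same 2-methoxyphenyl group that compound 4 carries; what the numbers show is the limit of > 100000 nM in this assay, at which 2 of the 3 values shown sit.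

Compound 4 `COc1ccccc1-c1cn(C/C=C2\OC(=O)C(OCc3ccccc3)=C2OCc2ccccc2)nn1` differs from compound 1 by 2-methoxyphenyl in place of 3,5-difluorophenyl on an aromatic carbon. Within the data shown here, no measured step gives a readable size for this kind of change, and every value shown so far is either an unquantified inactivity or a limit, so no movement beyond the usual scatter can be supported in either direction. Compound 4 is therefore expected to give roughly 150000 nM in this assay, within a range from 40000 nM to 600000 nM, and most probably only a limit will be reported.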

Compound 4, half-maximal inhibitory concentration: > 100000 nM
Compound 4: only a limit was reported; the forecaster's own chance of this, stated with the estimate: 80%; the middle value lies beyond the limit too.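

No new step can be read between compound 1 and compound 4: compound 1 has no number and compound 4 has only a limit. The compounds shown leave open which change to the shared core, if any, would give a measurable value in this assay rather than a limit.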